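Chloro-Methyl Aryl Ether Analogue of a Weak Binder

The source may report more compounds than this note shows. Statements on the series, on what has been measured and on what is new or still open speak of the compounds shown alone.

Compound 1: `CN1CCN(c2nc(N)nc(COc3ccccc3)n2)CC1`, 9530 nM
Compound 2: `Cc1cccc(OCc2nc(N)nc(N3CCN(C)CC3)n2)c1`, 10700 nM

Of the compounds shown here, two sharing the same core have been tested in an assay on HEK293 cells for displacement of a labelled ligand from 5-hydroxytryptamine receptor 7 (Homo sapiens), read by radioligand binding, with a stated time of 1 h; a lower number here means a stronger inhibitor, a higher number a weaker inhibitor. Compound 1 `CN1CCN(c2nc(N)nc(COc3ccccc3)n2)CC1` gives 9530 nM, and compound 2 `Cc1cccc(OCc2nc(N)nc(N3CCN(C)CC3)n2)c1` gives 10700 nM. Within the data shown here, the single step between them, a 1.1-fold higher number from compound 1 to compound 2 (0.05 log units; within the scatter), falls within the scatter, so the two numbers are indistinguishable: compound 2 holds the higher of the two numbers, but only nominally, and it stands on the same footing as compound 1.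

Compound 3 `Cc1cc(Cl)ccc1OCc1nc(N)nc(N2CCN(C)CC2)n1` differs from compound 2 in one place: 4-chloro-2-methylphenyl in place of 3-methylphenyl on an oxygen on a saturated carbon. Among the measured compounds shown here, no measured step touches the entry of chlorine, so the only guidance is the step from compound 1 to compound 2, which shows that moving methyl onto the aromatic ring left the number unchanged in this assay. The step into compound 3 adds chlorine on top of a shifted methyl, and it is therefore expected to bring at most a modest change, with an estimated step of a 1.5-fold lower number from compound 2 to compound 3 (0.18 log units; within the scatter). Compound 3 is expected to give 7000 nM in this assay, within a range of 2500 nM to 20000 nM.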

Compound 3, inhibition constant: 15200 nM
Estimate against measurement, compound 3: 2.2-fold (0.34 log units) below; measured number inside the range.
By their numbers in this assay, from the lowest: compounds 1, 2 and 3 (each within the scatter of the next).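

In this assay, among these compounds, the change to 4-chloro-2-methylphenyl on the oxygen is the first at this position to bring in a halogen and a second ring substituent, and the step is a 1.4-fold higher number from compound 2 to compound 3 (0.15 log units; within the scatter). Set against the plain phenyl of the core of compound 1, the same group gives a 1.6-fold higher number from compound 1 to compound 3 (0.20 log units; within the scatter), so even the largest change shown on this oxygen stays inside the scatter. The earlier pair showed this only for a single methyl, whereas the three aryl groups now cannot be told apart in this assay, and nothing at hand bears on why this position accepts these groups.

The compounds shown do not separate the contribution of the chlorine from that of the methyl in its new place, since both differ at once between compound 2 and compound 3. They also leave open whether a group of another kind on the aromatic ring, such as an amine or a carboxylic acid, or a longer chain in place of the aryl group on this oxygen, would give a number beyond the scatter of these three.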